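What a large sulfonyl group may do to cytotoxicity

The source may report more compounds than this note shows. Statements on the series, on what has been measured and on what is new or still open speak of the compounds shown alone.

Of the compounds shown here, three sharing one core have been measured in a functional assay on NCI-H460 cells (Homo sapiens) for cytotoxicity, read by MTT assay, with a stated time of 3 days; a lower number here means a stronger inhibitor, a higher number a weaker inhibitor. Compound 1 `N#Cc1c(Cl)nc(SCc2nc3ccccc3[nH]2)nc1-c1ccccc1`, with a chloro group, gives 3.28 nM. Compound 2 `N#Cc1c(Nc2nccs2)nc(SCc2nc3ccccc3[nH]2)nc1-c1ccccc1`, with (1,3-thiazol-2-yl)amino in its place, gives 3.37 nM. Compound 3 `N#Cc1c(-c2ccccc2)nc(SCc2nc3ccccc3[nH]2)nc1N1CCNCC1`, with piperazin-1-yl at that spot, gives 7.35 nM, the highest number of the three and so the weakest inhibitor here.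

Compound 4 `N#Cc1c(-c2ccccc2)nc(SCc2nc3ccccc3[nH]2)nc1N1CCN(S(=O)(=O)c2ccccc2[N+](=O)[O-])CC1` is built from compound 3 by putting (2-nitrophenyl)sulfonyl in place of hydrogen on an amine nitrogen in a ring. Going by the values given here, no measured compound carries a group on that nitrogen, so the evidence is indirect. The measured steps all exchanged a group on an aromatic carbon. Putting (1,3-thiazol-2-yl)amino in place of chloro was a 1.0-fold higher number from compound 1 to compound 2 (0.01 log units; within the scatter). Putting piperazin-1-yl in place of chloro was a 2.2-fold higher number from compound 1 to compound 3 (0.35 log units; beyond the scatter), and putting it in place of (1,3-thiazol-2-yl)amino was a 2.2-fold higher number from compound 2 to compound 3 (0.34 log units; beyond the scatter). Even whole-group exchanges such as a 2.2-fold higher number from compound 2 to compound 3 (0.34 log units; beyond the scatter) moved the number only modestly, so no step beyond the scatter is expected for compound 4, though the new group is large and the direction stays uncertain. The estimated change is a 1.5-fold lower number from compound 3 to compound 4 (0.17 log units; within the scatter). The estimated value of compound 4 is 5 nM, expected to fall between 1.8 nM and 15 nM.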

Compound 4, half-maximal inhibitory concentration: 3.7 nM
The estimate for compound 4 lay 1.4-fold (0.13 log units) above the measured number; the range from low to high includes it.
By their numbers in this assay, from the lowest: compounds 1, 2, 4 and 3 (each within the scatter of the next, the first and the last beyond it).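

Until compound 4, no compound shown carried anything on the ring nitrogen of the piperazin-1-yl group, so this position had not been tested. In this assay, putting (2-nitrophenyl)sulfonyl, with its 12 heavy atoms and one six-membered aromatic ring, in place of hydrogen on that nitrogen gives a 2.0-fold lower number from compound 3 to compound 4 (0.30 log units; within the scatter), so this large group leaves the number within the usual scatter of repeated measurements. The hydrogen on that nitrogen is therefore not needed to keep the number in this range, at least for this one replacement, and the same single step gives no reason to think that the nitrogen has to stay free. Nothing measured here offers an explanation for this result.

Going by these compounds alone, the single step cannot separate the part played by the sulfonyl link from that of the nitro-bearing ring, so phenylsulfonyl without the nitro group, or the small methylsulfonyl group, would be the direct comparison. As far as these compounds go, it also remains open whether the link itself matters, which an acetyl or benzoyl group on the same nitrogen, or a plain benzyl group, could begin to show.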